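A few compounds are considered here, and "the series" means these few. Any claim that something is new, unique, unknown or untested is made for them only; others in the source may bear on it.

Of the compounds shown here, three that share one core have been tested in an assay on CHO cells for displacement of a labelled ligand from 5-hydroxytryptamine receptor 1B (Homo sapiens); a lower number here means a stronger inhibitor, a higher number a weaker inhibitor. Compound 1 `CN(CC1CCN(CCCc2c[nH]c3ccc(-n4cnnc4)cc23)CC1)C(=O)Nc1ccccc1` gives 6.2 nM. Compound 2 `c1ccc(C2CCCCN2C2CCN(CCCc3c[nH]c4ccc(-n5cnnc5)cc34)CC2)cc1` gives 410 nM, and compound 3 `CN(Cc1cccs1)C1CCN(CCCc2c[nH]c3ccc(-n4cnnc4)cc23)CC1` gives 140 nM. Among these three numbers compound 3 stands second highest: its nearest neighbour is compound 2, whose number lies higher by a gap beyond the usual scatter of repeated measurements, and the furthest from it is compound 1, whose number lies far lower, well beyond that scatter.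

Compound 4 `CC(C)=CCN(C)C1CCN(CCCc2c[nH]c3ccc(-n4cnnc4)cc23)CC1` is the next compound to be measured. It differs from compound 3 in one place only, namely (2-methylprop-1-en-1-yl in place of thiophen-2-yl on a saturated chain carbon bound to an amine nitrogen). Among the measured compounds shown here, no pair of already measured compounds differs by exactly this change, so there is no directly comparable step from which its size could be read off; what can be said rests on the structural change alone and on the spread already seen in this assay . The expectation is a small move toward a higher number, of a size that may not reach beyond the scatter. Compound 4 is therefore estimated to give about 200 nM, with a likely range from 60 nM to 700 nM. That estimate corresponds to an expected step of a 1.4-fold higher number from compound 3 to compound 4 (0.15 log units; within the scatter).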

Compound 4, half-maximal inhibitory concentration: 41 nM
Estimate against measurement, compound 4: 4.9-fold (0.69 log units) above; measured number below the stated range.
By their numbers in this assay, from the lowest: compound 1; then compound 4; then compound 3; then compound 2.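

In this assay, exchanging thiophen-2-yl for 2-methylprop-1-en-1-yl gives a 3.4-fold lower number from compound 3 to compound 4 (0.53 log units; beyond the scatter), so what sits at this position does affect the number. An aromatic ring is not required there for the lower number: the entering group has no ring and no hetero atom, only a double bond outside aromatic rings, and it has 4 heavy atoms against the 5 of the group it replaces. No supporting evidence bears on why this exchange lowers the number.

A saturated 3-methylbutyl group in the same place could separate the contribution of the double bond from that of the branched carbon chain, while a phenyl or furan-2-yl group could show whether the higher number of compound 3 is specific to thiophen-2-yl or extends to other aromatic rings. Compound 1 and compound 2 differ from compound 4 in more than one place, so their steps cannot be read, and this single exchange sets no general trend for the series.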